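Hydrazone aryl variation on the hydroxybenzofuran hydrazide series

The compounds below may be only part of what the source reports. "The series", "measured", "known", "first", "only" and "open" are said of these compounds alone.

Compound 3 `Cc1c(C(=O)N/N=C\c2ccccc2)oc2cccc(O)c12` is the benchmark here. In a functional assay on PC-3 cells (Homo sapiens) for inhibition (on this read-out lower numbers stand for stronger inhibition and higher numbers for weaker inhibition), compound 3 gives 29200 nM, the lowest of the two numbers shown, and its nearest neighbour is compound 2 `COc1ccccc1/C=N\NC(=O)c1oc2cccc(O)c2c1C`, which in this assay gives 32700 nM; the step of a 1.1-fold lower number from compound 2 to compound 3 (0.05 log units; within the scatter) is within the scatter. Compound 1 `Cc1c(C(=O)N/N=C\c2ccco2)oc2cccc(O)c12` in this assay gives only a limit, >= 40000 nM, and it is a limit, not a number (the limit of >= 40000 nM in this assay, at which 1 of the 3 values shown sits). The steps of an at least 1.2-fold lower number from compound 1 to compound 2 (0.08 log units; that floor lies within the scatter) and an at least 1.3-fold lower number from compound 1 to compound 3 (0.13 log units; that floor lies within the scatter) likewise do not leave the scatter.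

Compound 4 `Cc1c(C(=O)N/N=C\c2ccc(O)cc2O)oc2cccc(O)c12` is not yet measured. The change from compound 3 is 2,4-dihydroxyphenyl in place of phenyl on a carbon with a double bond to nitrogen. Among the measured steps, those that bear on it are the exchanges of the aryl group on the carbon double-bonded to nitrogen, an at least 1.3-fold lower number from compound 1 to compound 3 (0.13 log units; that floor lies within the scatter) and a 1.1-fold lower number from compound 2 to compound 3 (0.05 log units; within the scatter); neither introduces a hydroxyl on that aryl group, and none of them exceeds the scatter. No step beyond the scatter is therefore expected in this assay for compound 4, with a fair chance of a limit, since one of the three values is already one (the limit of >= 40000 nM in this assay, at which 1 of the 3 values shown sits). For compound 4 the estimate in this assay is 28000 nM, within 10000 nM to 70000 nM, meaning an expected step of a 1.0-fold lower number from compound 3 to compound 4 (0.02 log units; within the scatter).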

Compound 4, half-maximal inhibitory concentration: 14800 nM
Compound 4: the middle estimate sits 1.9-fold (0.28 log units) above what was measured; the measured number falls inside the stated range.
By their numbers in this assay, from the lowest: compounds 4, 3 and 2 (each within the scatter of the next, the first and the last beyond it). At a limit, above all of these: compound 1.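

In this assay, going by these compounds alone, the exchange of aryl groups on the carbon with a double bond to nitrogen shows a step beyond the scatter for the first time: 2,4-dihydroxyphenyl in place of 2-methoxyphenyl gives a 2.2-fold lower number from compound 2 to compound 4 (0.34 log units; beyond the scatter) and so separates two compounds that differ only in this group. The same group in place of phenyl gives a 2.0-fold lower number from compound 3 to compound 4 (0.30 log units; within the scatter) and so does not separate compound 4 from compound 3, which goes against any reading of 2,4-dihydroxyphenyl as better than every other aryl group shown. In place of furan-2-yl it gives an at least 2.7-fold lower number from compound 1 to compound 4 (0.43 log units; beyond the scatter) and that step is only a floor, since compound 1 stands at a limit and not at a number: the limit of >= 40000 nM in this assay, at which 1 of the 4 values shown sits.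

Compound 4 is the only compound shown with hydroxyl groups on this aryl ring, so it stays open whether both are needed for the step or whether a single hydroxyl on the phenyl would give the same number. Going by these compounds, it also stays open how an amine or a carboxylic acid on that phenyl would read out in this assay at this place on the shared core.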